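Series notes: methylation of the hydroxy in compound 1

The source may hold more compounds than are shown below. What is called first, only, known or untested is meant among the compounds shown, and "the series" means these compounds.

Measured so far in an assay on isolated protein for inhibition of Indoleamine 2,3-dioxygenase 1 (Homo sapiens), read by spectrophotometry; on this read-out higher numbers stand for weaker inhibition and lower numbers for stronger inhibition:
- compound 1 `O=C(Cc1cccnc1)c1cc2c(O)cccc2[nH]1`: 83000 nM
- compound 2 `COc1ccc2[nH]c(C(=O)Cc3cccnc3)cc2c1O`: 63000 nM

Compound 1 and compound 2 give numbers in this assay that lie within the usual scatter of each other; the step of a 1.3-fold lower number from compound 1 to compound 2 (0.12 log units; within the scatter) adds a methoxy on an aromatic carbon and changes little. Both compounds carry the hydroxy on the shared core.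

Compound 3 `COc1cccc2[nH]c(C(=O)Cc3cccnc3)cc12` differs from compound 1 by methyl in place of hydrogen on an oxygen on an aromatic ring; the hydroxy of compound 1 becomes a methoxy. Going by the values given here, no measured step touches this oxygen, so the only comparison available is the substitution on an aromatic carbon, which stayed within the scatter. On that basis the step in this assay is expected to be a 1.2-fold higher number from compound 1 to compound 3 (0.08 log units; within the scatter), that is, none beyond the scatter in either direction. Compound 3 is therefore estimated at 100000 nM, with a range from 35000 nM to 300000 nM, the wide range reflecting that the hydroxy itself has not been varied in any measured pair.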

Compound 3, half-maximal inhibitory concentration: 58000 nM
Compound 3: the middle estimate sits 1.7-fold (0.24 log units) above what was measured; low and high end bracket the measured number.
By their numbers in this assay, from the lowest: compounds 3, 2 and 1 (each within the scatter of the next).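

Going by these compounds alone, this oxygen is now varied directly for the first time: in this assay, replacing the hydrogen on the oxygen with methyl gives a 1.4-fold lower number from compound 1 to compound 3 (0.16 log units; within the scatter). The hydroxy hydrogen is therefore not required for the activity seen with compound 1, since compound 3, which has a methoxy there, cannot be told apart from it in this read-out. No measurement at hand bears on what lies behind this result.

Still open, going by these compounds, is whether a larger group on this oxygen, such as benzyl or a longer chain, would move the number beyond the scatter. The same question applies to an amine or a carboxylic acid in place of the hydroxy, and to plain hydrogen there, which would show whether any oxygen is needed at this place on the shared core.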